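Exchanging the Aromatic Group on the Saturated Ring Carbon

This account rests on a few compounds, and the source may have more. Where it says the series, first, only, none or still open, it means among the compounds named here.

Of the compounds shown here, three built on one shared core have been measured in a functional assay; on this read-out lower numbers stand for stronger inhibition and higher numbers for weaker inhibition. Compound 1 `CC(C)=CCOc1ccc2c(c1)OC(c1ccccc1F)CC2=O` gives 6360 nM. Compound 2 `CC(C)=CCOc1ccc2c(c1)OC(c1cccc(Cl)c1)CC2=O` gives 6300 nM, the second highest of the three numbers, and compound 3 `CC(C)=CCOc1ccc2c(c1)OC(c1ccc(Cl)cc1Cl)CC2=O` gives 5260 nM. All three values sit within the scatter of one another: a 1.0-fold lower number from compound 1 to compound 2 (0.00 log units; within the scatter), a 1.2-fold lower number from compound 2 to compound 3 (0.08 log units; within the scatter) and a 1.2-fold lower number from compound 1 to compound 3 (0.08 log units; within the scatter).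

Compound 4 `COc1ccc(C2CC(=O)c3ccc(OCC=C(C)C)cc3O2)cc1` has not yet been measured. It differs from compound 2 in a single place: 4-methoxyphenyl in place of 3-chlorophenyl on a saturated ring carbon. Within the data shown here, the steps that bear on this change are those that exchanged the group on that same saturated ring carbon, namely a 1.0-fold lower number from compound 1 to compound 2 (0.00 log units; within the scatter) and a 1.2-fold lower number from compound 2 to compound 3 (0.08 log units; within the scatter); neither moved the number beyond the scatter. Because of a 1.0-fold lower number from compound 1 to compound 2 (0.00 log units; within the scatter) and a 1.2-fold lower number from compound 2 to compound 3 (0.08 log units; within the scatter), the expected step is no change at the digits printed from compound 2 to compound 4 (within the scatter), meaning no shift beyond the scatter in this assay. Compound 4 is accordingly estimated at 6300 nM, with a range from 3000 nM to 13000 nM.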

Compound 4, half-maximal inhibitory concentration: 10200 nM
Compound 4: middle estimate off by 1.6-fold (0.21 log units), on the low side; low and high end bracket the measured number.
By their numbers in this assay, from the lowest: compounds 3, 2, 1 and 4 (each within the scatter of the next).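

In this assay, 4-methoxyphenyl on this saturated ring carbon next to the ring oxygen stays within the scatter of all three chlorine- or fluorine-bearing phenyl groups (a 1.6-fold higher number from compound 2 to compound 4 (0.21 log units; within the scatter) and a 1.6-fold higher number from compound 1 to compound 4 (0.21 log units; within the scatter) and a 1.9-fold higher number from compound 3 to compound 4 (0.29 log units; within the scatter)). This extends the earlier picture: a phenyl group with no halogen, and the first entering group counted with a hydrogen-bond acceptor, still gives no step beyond the scatter, so all four compounds read alike at this position. Nothing available explains the size of these steps.

As far as these compounds go, whether an amine or a carboxylic acid on the phenyl ring would shift the number beyond the scatter remains open, as does the effect of a cyclohexyl ring in place of the phenyl ring. All four compounds also keep the rest of the shared core, so how these groups behave on a different core is open too.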